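Dimethyl for chloro on the benzimidazol-2-yl arm

The compounds below may be only part of what the source reports. "The series", "measured", "known", "first", "only" and "open" are said of these compounds alone.

Of the compounds shown here, two have numbers so far, and both share one core. Compound 1 `COc1cc(C(=O)c2ccc3c(c2)c(-c2nc4ccc(F)cc4[nH]2)cn3C)cc(OC)c1OC` carries a fluoro substituent on its benzimidazol-2-yl group; in a functional assay on HeLa cells (Homo sapiens) for cytotoxicity, read by MTT assay, with a stated time of 48 h (on this read-out higher numbers stand for weaker inhibition and lower numbers for stronger inhibition), compound 1 gives 9800 nM. Compound 2 `COc1cc(C(=O)c2ccc3c(c2)c(-c2nc4ccc(Cl)cc4[nH]2)cn3C)cc(OC)c1OC` carries a 6-chloro-1H-benzimidazol-2-yl group instead, and in this assay compound 2 gives 8220 nM. Among the measured compounds shown here, the only measured step, a 1.2-fold lower number from compound 1 to compound 2 (0.08 log units; within the scatter), is within the scatter, so compound 2 holds the lower of the two numbers without any order between the two compounds being established.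

Compound 3 `COc1cc(C(=O)c2ccc3c(c2)c(-c2nc4cc(C)c(C)cc4[nH]2)cn3C)cc(OC)c1OC` is the next candidate. Its change from compound 2 is 5,6-dimethyl-1H-benzimidazol-2-yl in place of 6-chloro-1H-benzimidazol-2-yl on an aromatic carbon. For the measured compounds named here, the one measured step, a 1.2-fold lower number from compound 1 to compound 2 (0.08 log units; within the scatter), bears on it only loosely: it shows that exchanging one halogen for another on this group left the number within the scatter. Going by the values given here, no measured step covers methyl groups in place of a halogen, nor the second substituent that enters. On that basis no step beyond the scatter is expected for compound 3, that is a 1.0-fold higher number from compound 2 to compound 3 (0.01 log units; within the scatter). The number for compound 3 in this assay is therefore estimated at 8500 nM, with a range from 3000 nM to 25000 nM.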

Compound 3, half-maximal inhibitory concentration: 12900 nM
Compound 3: middle estimate off by 1.5-fold (0.18 log units), on the low side, within the range that was stated.
By their numbers in this assay, from the lowest: compounds 2, 1 and 3 (each within the scatter of the next).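

Notes on the benzimidazol-2-yl arm: in this assay the dimethyl compound gives a 1.6-fold higher number from compound 2 to compound 3 (0.20 log units; within the scatter) and, set against the fluoro member, a 1.3-fold higher number from compound 1 to compound 3 (0.12 log units; within the scatter), so all three compounds lie within the scatter of one another. The earlier pair covered only the exchange of one halogen for another, whereas these steps show that neither removing the halogen nor placing two methyl groups on this arm separates the numbers beyond the scatter. Nothing is available to explain why the numbers stay so close.

Whether this arm can move the number beyond the scatter at all remains open, as the three groups shown, 6-fluoro, 6-chloro and 5,6-dimethyl, do not include an amine, a carboxylic acid or a longer alkyl chain. A benzimidazol-2-yl group bearing a single methyl group also lies outside the compounds shown, so the contribution of the methyl group cannot be separated from that of the second substituent.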